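This account rests on a few compounds, and the source may have more. Where it says the series, first, only, none or still open, it means among the compounds named here.

Compound 1 `COc1cc(/C=C/C(=O)c2sc(Nc3ccccc3C)nc2C)cc(OC)c1OC` gives 5400 nM in a functional assay on BGC-823 cells (Homo sapiens) for cytotoxicity, read by MTT assay; a higher number here means a weaker inhibitor, a lower number a stronger inhibitor.
Compound 2 `Cc1cccc(Nc2nc(C)c(C(=O)/C=C/c3ccc(Cl)cc3)s2)c1` gives > 25000 nM, which is a limit of the assay rather than a number.
Compound 3 `Cc1cccc(Nc2nc(C)c(C(=O)/C=C/c3ccccc3Cl)s2)c1` gives 24200 nM.

All three share one core and differ only at their outer rings. Among the two numbers known, compound 3 stands highest; the nearest is compound 1, whose lower number sits beyond the scatter of repeated measurements. The only step measured between two of these compounds is an at least 1.0-fold lower number from compound 2 to compound 3 (0.01 log units; that floor lies within the scatter), which lies within the scatter. That step concerns the chlorophenyl ring on the double-bonded chain, not the ring carrying the amine.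

Compound 4 `Cc1nc(Nc2ccccc2)sc1C(=O)/C=C/c1ccccc1Cl` has not yet been measured. Its difference from compound 3 is hydrogen in place of methyl on an aromatic carbon. Among the compounds with values here, no measured step touches this methyl group, so nothing among the known values points to a change in either direction. The expected step is therefore none beyond the scatter, given as a 1.0-fold lower number from compound 3 to compound 4 (0.00 log units; within the scatter). Compound 4 is estimated to give 24000 nM in this assay, expected to fall between 9000 nM and 60000 nM.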

Compound 4, half-maximal inhibitory concentration: 22800 nM
Compound 4: middle estimate off by 1.1-fold (0.02 log units), on the high side; the range from low to high includes it.
By their numbers in this assay, from the lowest: compound 1; then compounds 4 and 3 (each within the scatter of the next). At a limit, above all of these: compound 2.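

The change from 3-methylphenyl to phenyl on the amine gives a 1.1-fold lower number from compound 3 to compound 4 (0.03 log units; within the scatter) in this assay. Within the data shown here, this is the first measured step on this ring, as the only earlier step concerned the chlorophenyl ring at the other end of the molecule, and it shows that with a 2-chlorophenyl at that end, this methyl group can be removed without a change that stands out from the scatter. Compound 2 remains a limit and not a number: the limit of > 25000 nM in this assay, at which 1 of the 4 values shown sits.

Open, on these data alone, is whether a different group on this aromatic carbon, such as an ethyl chain, an amine or a carboxylic acid, would move the number beyond the scatter. Also open, as far as these compounds go, is whether removing this methyl group would have as little effect with a different group at the other end of the molecule.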